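Replacing a Boc-Pyrrolidine with a Glycolamide-Bearing Phenyl Ring

The compounds below may be only part of what the source reports. "The series", "measured", "known", "first", "only" and "open" are said of these compounds alone.

Going by the values given here, compound 1 `CN1CCN(c2ccc(Nc3ncc4nc(Nc5ccc(F)cc5)n([C@H]5CCCN(S(=O)(=O)C6CC6)C5)c4n3)cc2)CC1` is the only member of this small set with a number: in a functional assay on A549 cells (Homo sapiens) for antiproliferative activity, read by MTT assay, with a stated time of 72 h (on this read-out lower numbers stand for stronger inhibition and higher numbers for weaker inhibition), compound 1 gives 1320 nM. Compound 2 `CCOC(=O)CN1CC[C@H](n2c(Nc3ccc(F)cc3)nc3cnc(Nc4ccc(N5CCN(C)CC5)cc4)nc32)C1` and compound 3 `CN1CCN(c2ccc(Nc3ncc4nc(Nc5ccc(F)cc5)n([C@H]5CCN(C(=O)OC(C)(C)C)C5)c4n3)cc2)CC1` were run without a reported result: in this assay compound 2 gives "not determined" (no result reported), and in this assay compound 3 gives "not determined" (no result reported), so compound 3 stands with no value of its own and nothing to rank it against. Compound 4 `CN1CCN(c2ccc(Nc3ncc4nc(Nc5ccc(F)cc5)n(-c5cccc(NC(=O)CO)c5)c4n3)cc2)CC1` differs from compound 3 in one place: 3-(((hydroxymethyl)carbonyl)amino)phenyl in place of 1-(tert-butoxycarbonyl)pyrrolidin-3-yl on an aromatic nitrogen. Among the compounds with values here, with no measured pair to calibrate this change, only a modest shift is expected, likely no larger than the usual scatter and, if anything, toward stronger inhibition relative to what compound 1 shows. Compound 4 is therefore estimated to give 800 nM in this assay, within a range of 150 nM to 4000 nM.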

Compound 4, half-maximal inhibitory concentration: 1510 nM
Beside the measured number, compound 4's estimate is 1.9-fold (0.28 log units) below it; the measured number falls inside the stated range.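

In this assay, the position on the aromatic nitrogen now has a comparison: exchanging 1-(cyclopropylsulfonyl)piperidin-3-yl for 3-(((hydroxymethyl)carbonyl)amino)phenyl gives a 1.1-fold higher number from compound 1 to compound 4 (0.06 log units; within the scatter). This position therefore accepts either a six-membered aromatic ring of carbon only or a substituted non-aromatic ring with no separation in this read-out. No measurement offered here explains that match.

From the compounds shown here alone, it remains open whether an amine or a carboxylic acid in place of the hydroxyl of the hydroxymethyl group would move the number beyond the scatter. A longer chain on the amide carbonyl is equally unresolved.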